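The source may hold more compounds than are shown below. What is called first, only, known or untested is meant among the compounds shown, and "the series" means these compounds.

Measured so far in a functional assay (Homo sapiens) for antiproliferative activity, read by sulforhodamine B assay, with a stated time of 48 h; a higher number here means a weaker inhibitor, a lower number a stronger inhibitor:
compound 1 `O=C1NCCN1c1ccc(S(=O)(=O)Nc2ccc3[nH]ccc3c2)cc1`: 770 nM
compound 2 `Cc1cccc(NS(=O)(=O)c2ccc(N3CCNC3=O)cc2)c1`: 290 nM
compound 3 `CCc1cccc(NS(=O)(=O)c2ccc(N3CCNC3=O)cc2)c1`: 270 nM

Compound 3 shares the low end of these numbers with compound 2, the two lying within the scatter of each other. Compound 1 stands higher than compound 3, beyond the scatter. Compound 4 `O=C1NCCN1c1ccc(S(=O)(=O)Nc2cccc(Br)c2)cc1` has not yet been measured in this assay. Its difference from compound 3 is bromo in place of ethyl on an aromatic carbon.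

For the measured compounds named here, only one measured step bears on this change, a 1.1-fold lower number from compound 2 to compound 3 (0.03 log units; within the scatter). That step, methyl in place of hydrogen on a saturated chain carbon bound to an aromatic carbon, produced the ethyl that now leaves, and it stayed within the scatter. Going by the values given here, no measured compound carries a bromo, so the data give no direct reading of that group. The starting point is therefore compound 3 at 270 nM, and no shift beyond the scatter is expected. The expected step is a 1.0-fold higher number from compound 3 to compound 4 (0.02 log units; within the scatter). For compound 4 the estimated value is 280 nM, with an expected range from 120 nM to 650 nM.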

Compound 4, half-maximal inhibitory concentration: 270 nM
Compound 4: middle estimate off by 1.0-fold (0.02 log units), on the high side; measured number inside the range.
By their numbers in this assay, from the lowest: compounds 3, 4 and 2 (each within the scatter of the next); then compound 1.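

In this assay, the position held by the ethyl of the 3-ethylphenyl group now carries a halogen rather than a carbon chain, and bromo in place of ethyl gives no change at the digits printed from compound 3 to compound 4 (within the scatter). Bromo in place of methyl likewise gives a 1.1-fold lower number from compound 2 to compound 4 (0.03 log units; within the scatter), so methyl, ethyl and bromo on this aromatic carbon all lie within the scatter of one another across compounds 2, 3 and 4, a reading that holds for these three compounds only. No measurement at hand explains this agreement between the groups.

As far as these compounds go, whether the numbers would stay within the scatter with an amine, a carboxylic acid or a longer chain such as butyl at this place remains open. Also open, from the compounds shown here alone, is whether bromo would give the same reading on another carbon of this ring.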